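The source may report more compounds than this note shows. Statements on the series, on what has been measured and on what is new or still open speak of the compounds shown alone.

Measured in a functional assay on QG-56 cells (Homo sapiens) for antiproliferative activity; a lower number here means a stronger inhibitor, a higher number a weaker inhibitor:
- compound 1 `Cn1cncc1C(O)(c1ccc(C#N)cc1)c1cc2cc([N+](=O)[O-])cc(-c3ccccc3F)c2o1`: 89.5 nM
- compound 2 `COc1ccc(-c2cc([N+](=O)[O-])cc3cc(C(O)(c4ccc(C#N)cc4)c4cncn4C)oc23)cc1`: 36 nM

Of the two, compound 2 has the lower number, 36 nM. Compound 3 `Cn1cncc1C(O)(c1ccc(C#N)cc1)c1cc2cc([N+](=O)[O-])cc(-c3cccc(F)c3)c2o1` carries 3-fluorophenyl in place of 4-methoxyphenyl on an aromatic carbon. Among the compounds with values here, the one measured step bearing on this is a 2.5-fold lower number from compound 1 to compound 2 (0.40 log units; beyond the scatter), which put 4-methoxyphenyl in place of 2-fluorophenyl. Nothing measured yet separates 3-fluorophenyl from 2-fluorophenyl, so a modest rise of similar size is expected in this assay. The expected step is a 2.1-fold higher number from compound 2 to compound 3 (0.32 log units; beyond the scatter). For compound 3 the estimate is 75 nM, with an expected range of 30 nM to 185 nM.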

Compound 3, half-maximal inhibitory concentration: 145 nM
Compound 3: the middle estimate sits 1.9-fold (0.29 log units) below what was measured; the range from low to high includes it.
By their numbers in this assay, from the lowest: compound 2; then compounds 1 and 3 (each within the scatter of the next).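

In this assay, 3-fluorophenyl in place of 4-methoxyphenyl gives a 4.0-fold higher number from compound 2 to compound 3 (0.61 log units; beyond the scatter), a larger step than the one seen earlier between 2-fluorophenyl and 4-methoxyphenyl. Shifting the fluorine from 2-fluorophenyl to 3-fluorophenyl gives a 1.6-fold higher number from compound 1 to compound 3 (0.21 log units; within the scatter), so the two fluorophenyl groups are not told apart at this position, and 4-methoxyphenyl stays ahead of both. No measured evidence accounts for this difference. Still open, from the compounds shown here alone, is whether the gain depends on the methoxy group itself or on its place on the ring, which a 3-methoxyphenyl or a 4-fluorophenyl would test, and whether a 4-aminophenyl would match it.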